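A few compounds are considered here, and "the series" means these few. Any claim that something is new, unique, unknown or untested is made for them only; others in the source may bear on it.

For the measured compounds named here, in a functional assay on CHO cells for antagonist activity at transient receptor potential cation channel subfamily V member 1 (Rattus norvegicus) (a higher number here means a weaker inhibitor, a lower number a stronger inhibitor), compound 1 `CC(C(=O)NCc1ccc(Cl)c(Cl)c1)c1ccc(NS(C)(=O)=O)c(F)c1` gives 115 nM, the lowest of the two numbers known so far. Compound 2 `CC(C(=O)NCc1ccc2ccccc2c1)c1ccc(NS(C)(=O)=O)c(F)c1` gives 240 nM in this assay, a value separated from that of compound 1 by more than the usual scatter. Going by the values given here, no single-point step between measured compounds is available to calibrate the next change.

Compound 3 `CC(C(=O)NCCCc1ccc(Cl)cc1)c1ccc(NS(C)(=O)=O)c(F)c1` differs from compound 1 in one place: 2-(4-chlorophenyl)ethyl in place of 3,4-dichlorophenyl on a saturated chain carbon bound to an amide-type nitrogen. The chain that carries the aromatic ring is thus lengthened, and one of the two chlorines is removed. Among the compounds with values here, nothing among the measured compounds probes a longer linker of this kind, so the direction is uncertain; on the basis that compound 1 at 115 nM already holds the best number seen, a modest weakening is expected, with the step from compound 1 to compound 3 in this assay estimated at a 2.6-fold higher number from compound 1 to compound 3 (0.42 log units; beyond the scatter). Compound 3 is therefore expected to give about 300 nM in this assay, within a range from 100 nM to 1000 nM.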

Compound 3, inhibition constant: 135 nM
Compound 3: middle estimate off by 2.2-fold (0.35 log units), on the high side; the measured number falls inside the stated range.
By their numbers in this assay, from the lowest: compounds 1, 3 and 2 (each within the scatter of the next, the first and the last beyond it).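

The exchange of 3,4-dichlorophenyl for 2-(4-chlorophenyl)ethyl on a saturated chain carbon bound to an amide-type nitrogen amounts, in this assay, to a step (a 1.2-fold higher number from compound 1 to compound 3 (0.07 log units; within the scatter)) that cannot be told from repeat measurement, so this position tolerates the exchange with no detectable loss in this assay. The earlier compounds shown here held the chain length fixed, whereas this pair shows that the aromatic ring can be carried on a longer chain, with one chlorine fewer, and the number still stays level with that of compound 1. The exchange alters two things at once, the chain and the chlorine count, and this single step cannot show whether each is silent on its own or whether the two offset each other, and no measured property of either group is at hand to account for the result.

As far as these compounds go, it remains open how a 4-chlorophenyl group would read on the shorter chain of compound 1, or a 3,4-dichlorophenyl group on the longer chain of compound 3. From the compounds shown here alone, it is also open how far the chain can be extended, for instance by a further methylene unit, and whether a terminal amine or carboxylic acid in place of the chlorinated ring would be tolerated here.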